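A Trifluorophenyl Ring Replaces the Methoxyphenyl Group

The compounds below may be only part of what the source reports. "The series", "measured", "known", "first", "only" and "open" are said of these compounds alone.

Compound 1 `COc1cccc(/C=C/C(=O)Nc2cc(C(=O)c3cc(OC)c(OC)c(OC)c3)ccc2OC)c1` and compound 2 `COc1cccc(/C=C/C(=O)Nc2cc(C(=O)c3cc(OC)c(OC)c(OC)c3)cc(OC)c2OC)c1` share one core and differ in a single place, a methoxy in place of hydrogen on an aromatic carbon. In a functional assay on DU-145 cells (Homo sapiens) for cytotoxicity, read by MTT assay, with a stated time of 72 h (a lower number here means a stronger inhibitor, a higher number a weaker inhibitor), compound 1 gives 6200 nM, and compound 2 gives 12500 nM. The step of a 2.0-fold higher number from compound 1 to compound 2 (0.30 log units; within the scatter) is within the scatter, so although compound 2 carries the higher of the two numbers, no order between the two can be read from them.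

Compound 3 `COc1cc(C(=O)c2cc(OC)c(OC)c(OC)c2)cc(NC(=O)/C=C/c2cc(F)c(F)c(F)c2)c1OC` differs from compound 2 by 3,4,5-trifluorophenyl in place of 3-methoxyphenyl on a double-bonded chain carbon bound to a double-bonded chain carbon. Within the data shown here, no measured step touches this part of the molecule; the only step available concerns the core and lies within the scatter, so it offers no guide to this change. The author therefore expects a step of a 1.3-fold lower number from compound 2 to compound 3 (0.10 log units; within the scatter) in this assay, with wide uncertainty in either direction. For compound 3 the estimate in this assay is 10000 nM, in a range from 2500 nM to 40000 nM.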

Compound 3, half-maximal inhibitory concentration: 7900 nM
Beside the measured number, compound 3's estimate is 1.3-fold (0.10 log units) above it; measured number inside the range.
By their numbers in this assay, from the lowest: compounds 1, 3 and 2 (each within the scatter of the next).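

Among these compounds, compound 3 gives the first reading at this end of the molecule. In this assay the exchange of 3-methoxyphenyl for 3,4,5-trifluorophenyl on a double-bonded chain carbon bound to a double-bonded chain carbon gives a 1.6-fold lower number from compound 2 to compound 3 (0.20 log units; within the scatter) and so lies within the scatter, which means this read-out does not separate the two groups, although the leaving group counts 1 hydrogen-bond acceptor and the entering group 0. No information at hand bears on the reason for this result.

From the compounds shown here alone, whether a group such as a phenyl ring carrying an amine or a carboxylic acid would move the number beyond the scatter at this place stays open. Going by these compounds, it also stays open whether the same exchange would read alike on the core of compound 1.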